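Aryl extension at the benzyl position of the coumarin-amide series

A few compounds are considered here, and "the series" means these few. Any claim that something is new, unique, unknown or untested is made for them only; others in the source may bear on it.

Going by the values given here, compound 2 `Cc1c(Cc2ccc(F)cc2)c(=O)oc2cc(OCC(O)CN3CCC(C(N)=O)CC3)ccc12` gives 89300 nM in an ADME assay on A549 cells (Homo sapiens) for cytotoxicity, read by CellTiter-Glo (a lower number here means that less compound is tolerated, a higher number that more compound is tolerated), the second highest of the three numbers so far. Compound 3 `Cc1c(Cc2ccc(F)cc2Cl)c(=O)oc2cc(OCC(O)CN3CCC(C(N)=O)CC3)ccc12` gives 90800 nM, within the scatter of compound 2; compound 1 `Cc1c(Cc2ccccc2)c(=O)oc2cc(OCC(O)CNC3CCOCC3)ccc12` gives 38200 nM, a number beyond the scatter below compound 2.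

Compound 4 `Cc1c(Cc2ccc(-c3ccc(C=O)c(F)c3)cc2)c(=O)oc2cc(OCC(O)CN3CCC(C(N)=O)CC3)ccc12` carries the change (3-fluoro-4-formylphenyl in place of fluoro on an aromatic carbon). Among the compounds with values here, the only measured step at this aromatic carbon, a 1.0-fold higher number from compound 2 to compound 3 (0.01 log units; within the scatter), was within the scatter, but it exchanged a single atom, whereas here a whole substituted ring enters; no measured step tells what such a growth does here. A modestly lower number is expected, with wide uncertainty: the step of a 2.0-fold lower number from compound 2 to compound 4 (0.30 log units; within the scatter) is the estimate. Compound 4 is therefore expected at 45000 nM, within 15000 nM to 100000 nM.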

Compound 4, half-maximal cytotoxic concentration: 62400 nM
Compound 4: the middle estimate sits 1.4-fold (0.14 log units) below what was measured; the measured number falls inside the stated range.
By their numbers in this assay, from the lowest: compounds 1, 4, 2 and 3 (each within the scatter of the next, the first and the last beyond it).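

At this aromatic carbon, para to a large group, a whole 3-fluoro-4-formylphenyl takes the place of fluoro, and in this assay the result is a 1.4-fold lower number from compound 2 to compound 4 (0.16 log units; within the scatter). Going by these compounds alone, the position therefore takes an added aromatic ring with a step that stays within the scatter, which the single-atom exchange in the earlier compounds could not show. No measurement at hand bears on the reason for this result.

The compounds shown do not separate the contribution of the formyl group from that of the added ring or its fluoro. As far as these compounds go, an amine or a carboxylic acid in place of formyl on that ring remains open.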